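The compounds below may be only part of what the source reports. "The series", "measured", "known", "first", "only" and "open" are said of these compounds alone.

Measured so far in an ADME assay on HepG2 cells (Homo sapiens) for cytotoxicity, read by luminescence, with a stated time of 72 h; on this read-out higher numbers stand for an effect only at larger amounts of compound and lower numbers for an effect already at smaller amounts:
Compound 1 `CCOC(=O)c1c(-c2ccccc2)[nH]c2cc(OC)ccc2c1=O`: > 21500 nM (a limit)
Compound 2 `CCOC(=O)c1c(-c2cccc(OC(F)(F)F)c2)[nH]c2cc(OC)ccc2c1=O`: > 21500 nM (a limit)
Compound 3 `CCOC(=O)c1c(-c2cccc(S(C)(=O)=O)c2)[nH]c2cc(OC)ccc2c1=O`: > 21500 nM (a limit)

Compound 2 has no exact number, only > 21500 nM, which is a limit. It shares this position with the other two compounds: the limit of > 21500 nM in this assay, at which 3 of the 3 values shown sit.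

Compound 4 `CCOC(=O)c1c(-c2cccc(OC(F)(F)F)c2)[nH]c2cc(OC)c(F)cc2c1=O` is compound 2 with one change: fluoro in place of hydrogen on an aromatic carbon. In words, fluoro takes the place of hydrogen on an aromatic carbon, ortho to a methoxy group.

Within the data shown here, three measured steps bear on this: a step that the two limits leave unreadable from compound 1 to compound 2, a step that the two limits leave unreadable from compound 1 to compound 3 and a step that the two limits leave unreadable from compound 2 to compound 3. None of them has a readable size and none adds fluoro, so they offer only weak guidance. They show no change that can be read in this assay, and no step beyond the scatter is expected here, in either direction. The estimated change is a number no higher from compound 2 to compound 4 (the limit leaves the size open). Compound 4 is expected at about 21500 nM, with an estimated range of 9000 nM to 45000 nM, and it may well be reported as a limit again.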

Compound 4, half-maximal effective concentration: > 21500 nM
Compound 4 ended at the assay's limit; the forecaster's own chance of this, stated with the estimate: 75%; the middle value sits exactly at the limit.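

No new step can be read, since compound 2 and compound 4 both stand only as limits and not as numbers: the limit of > 21500 nM in this assay, at which 4 of the 4 values shown sit.

The compounds shown leave open how far fluoro in place of hydrogen shifts the read-out, and at what amount, if any, each of the four compounds would show an effect.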